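A few compounds are considered here, and "the series" means these few. Any claim that something is new, unique, unknown or untested is made for them only; others in the source may bear on it.

Compound 2 `C[C@H](c1ccc(F)cc1)N(Cc1cccc(C(=O)O)n1)C(=O)c1cnc2ccccc2c1` stands at the higher of the two numbers obtained so far in an assay on CHO T-rex cells for antagonist activity at transient receptor potential cation channel subfamily M member 8 (Homo sapiens), read by calcium flux, with a stated time of 20 min; on this read-out higher numbers stand for weaker inhibition and lower numbers for stronger inhibition: compound 2 gives 1160 nM, whereas compound 1 `C[C@H](c1ccc(F)cc1)N(Cc1cccc(C(=O)O)c1)C(=O)c1cc2ccccc2nn1` gives 340 nM in this assay, and that gap lies beyond the usual scatter. The two compounds differ in more than one place, so only their two values can be compared. Compound 3 `C[C@H](c1ccc(F)cc1)N(Cc1cccc(-c2nn[nH]n2)c1)C(=O)c1cnc2ccccc2c1` is derived from compound 2 by a single exchange: 3-(2H-tetrazol-5-yl)phenyl in place of 6-carboxypyridin-2-yl on a saturated chain carbon bound to an amide-type nitrogen. Among the compounds with values here, no measured pair shows this change on its own, so the step from compound 2 to compound 3 can only be estimated. In this assay the step of a 2.1-fold lower number from compound 2 to compound 3 (0.32 log units; beyond the scatter) is expected to be modest and to run towards a lower number, with a real chance that it stays within the scatter. Compound 3 is accordingly expected to give about 550 nM in this assay, with a likely range from 180 nM to 1700 nM.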

Compound 3, half-maximal inhibitory concentration: 1610 nM
For compound 3 the middle estimate is 2.9-fold (0.47 log units) below the measured one; the range from low to high includes it.
By their numbers in this assay, from the lowest: compound 1; then compounds 2 and 3 (each within the scatter of the next).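

In this assay, placing 3-(2H-tetrazol-5-yl)phenyl in place of 6-carboxypyridin-2-yl on a saturated chain carbon bound to an amide-type nitrogen gives a 1.4-fold higher number from compound 2 to compound 3 (0.14 log units; within the scatter). Within the data shown here, this is the first comparison that isolates a single place, and it shows that the two groups cannot be told apart on this read-out, even though they differ in ring make-up and size. Nothing at hand explains why the exchange leaves the result within the scatter.

The compounds shown leave open how a methyl ester or a primary amide would read at this place, and whether the two groups would also match on the core of compound 1. Compound 1 differs from compound 2 and compound 3 in more than one place, so its value cannot be assigned to any single part of its structure.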